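Swapping fluoro for acetamido on the aromatic end

The compounds below may be only part of what the source reports. "The series", "measured", "known", "first", "only" and "open" are said of these compounds alone.

- compound 1 `CCc1ccc(OCCCN2CCC(C(c3ccc(F)cc3)c3ccc(F)cc3)CC2)c(OC)c1` gives 2.51 nM
- compound 2 `Fc1ccc(OCCCN2CCC(C(c3ccc(F)cc3)c3ccc(F)cc3)CC2)cc1` gives 1.26 nM

Both values come from a functional assay (aorta) with Oryctolagus cuniculus as the target; on this read-out higher numbers stand for weaker binding and lower numbers for tighter binding. They lie within the usual scatter of each other, so compound 2 stands level with compound 1 on the numbers available, and the two cannot be told apart.

Compound 3 `CC(=O)Nc1ccc(OCCCN2CCC(C(c3ccc(F)cc3)c3ccc(F)cc3)CC2)cc1` keeps the shared core of compound 2 and alters only one end of the molecule: acetamido in place of fluoro on an aromatic carbon. Put simply, this is 4-fluorophenoxy becoming 4-acetamidophenoxy, with acetamido in place of fluoro on an aromatic carbon.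

Within the data shown here, only one measured step bears on this change. It is a 2.0-fold lower number from compound 1 to compound 2 (0.30 log units; within the scatter) and it exchanged the group on the same oxygen. With that single small step as the guide, no step beyond the scatter is expected in this assay for compound 3. Among the measured compounds shown here, still, no measured compound carries an acetamido group, and one step is thin evidence, so the range is kept wide.

The estimated change is a 2.0-fold higher number from compound 2 to compound 3 (0.30 log units; within the scatter) and counts as small. Compound 3 is expected at 2.5 nM with an estimated range from 0.8 nM to 8 nM.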

Compound 3, dissociation constant: 12.6 nM
Beside the measured number, compound 3's estimate is 5.0-fold (0.70 log units) below it; measured number outside the range, above it.
By their numbers in this assay, from the lowest: compounds 2 and 1 (each within the scatter of the next); then compound 3.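

In this assay, the group on this aromatic carbon turns out to matter: acetamido in place of fluoro gives a 10-fold higher number from compound 2 to compound 3 (1.00 log units; beyond the scatter), a step beyond the scatter, whereas the earlier exchange of the group on the same oxygen stayed within it. The 4-acetamidophenyl end also stands apart from the 4-ethyl-2-methoxyphenyl end, with a 5.0-fold higher number from compound 1 to compound 3 (0.70 log units; beyond the scatter), so compound 3 has the highest number of the three, which on this read-out means the weakest binding. Nothing available here explains why this one exchange moves the number so much more than the earlier one.

Still open, as far as these compounds go, is whether the higher number belongs to acetamido in particular or would also appear with other groups on this aromatic carbon, such as a plain amine, a carboxylic acid or a longer amide like propionamido. From the compounds shown here alone, it is also open which part of acetamido goes with the step, the amide hydrogen or the carbonyl, and a version with a methyl group on the amide nitrogen would help separate the two.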